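A Nitro Thiosemicarbazone Drawn Without Its Double-Bond Configuration

This account rests on a few compounds, and the source may have more. Where it says the series, first, only, none or still open, it means among the compounds named here.

- compound 1 `C/C(=N\NC(=S)Nc1ccc(Cl)cc1)c1ccccn1` gives 8.49 nM
- compound 2 `C/C(=N\NC(=S)Nc1ccc(F)cc1)c1ccccn1` gives 1.2 nM
- compound 3 `C/C(=N\NC(=S)Nc1ccc([N+](=O)[O-])cc1)c1ccccn1` gives 52 nM

All three compounds were read in a functional assay on MCF7 cells (Homo sapiens) for cytotoxicity, read by MTT assay, with a stated time of 48 h; on this read-out lower numbers stand for stronger inhibition and higher numbers for weaker inhibition. They differ only in the group on the aromatic ring that carries chloro, fluoro or nitro. Compound 3 has the highest number of the three, 52 nM, and is therefore the weakest of this small set. The measured steps show this as a 6.1-fold higher number from compound 1 to compound 3 (0.79 log units; beyond the scatter) and a 43-fold higher number from compound 2 to compound 3 (1.64 log units; beyond the scatter). The remaining step is a 7.1-fold lower number from compound 1 to compound 2 (0.85 log units; beyond the scatter).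

Compound 4 `CC(=NNC(=S)Nc1ccc([N+](=O)[O-])cc1)c1ccccn1` stands apart from these comparisons, since it keeps the nitro group of compound 3. The difference is the two compounds have the same atoms and bonds; at least one stereo element is drawn with a configuration in one of them and without one in the other: 1 of 1 stereo elements differ; a double bond is drawn E in compound 3 and without a configuration in compound 4. None of the three measured steps touches that double bond. Going by the values given here, they all concern the aromatic group, so their size says nothing about this change, and no measured pair tests it directly. The data also do not show which configuration the sample of compound 4 actually holds.

Among the compounds with values here, with the same atoms and bonds, the only anchor is compound 3 at 52 nM, so no shift beyond the scatter is expected in this assay. The expected step is no change at the digits printed from compound 3 to compound 4 (within the scatter). For compound 4 the estimated value is 52 nM, with an expected range from 25 nM to 110 nM.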

Compound 4, half-maximal inhibitory concentration: 52 nM
For compound 4 middle estimate and measured number coincide at the digits printed; the measured number falls inside the stated range.
By their numbers in this assay, from the lowest: compound 2; then compound 1; then compounds 3 and 4 (each within the scatter of the next).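

In this assay, going by these compounds alone, the one step that touches the double bond rather than the aromatic group is no change at the digits printed from compound 3 to compound 4 (within the scatter), so removing the drawn configuration goes with no shift in the number. The earlier steps shown here all exchanged chloro, fluoro and nitro on the aromatic ring and could say nothing about this double bond, whereas this pair isolates it, and the only thing that separates the two records is a matter of drawing: the fact that one of compounds 3 and 4 is drawn with a defined configuration and the other without, at the place where they differ. This is therefore not a comparison of two configurations, as compound 4 may be the same material as compound 3 drawn less fully, or it may be a different form or mixture that reads alike.

Still open, on these data alone, is which configuration the sample of compound 4 actually holds, and whether a compound drawn Z at that double bond would give a different number in this assay. Also open, as far as these compounds go, is how the number responds when an amine, a carboxylic acid or a methoxy group stands in place of chloro, fluoro and nitro on the aromatic ring.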